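Pyrrolidin-1-yl for methyl(propyl)amino: cytotoxicity across two cores

The source may hold more compounds than are shown below. What is called first, only, known or untested is meant among the compounds shown, and "the series" means these compounds.

Notes on the series in an ADME assay on MT4 cells (Homo sapiens) for cytotoxicity, read by MTT assay, with a stated time of 4 days; on this read-out lower numbers stand for higher toxicity in this test and higher numbers for lower toxicity in this test. Compound 1 `CCCN(C)c1nc(Cc2c(F)cccc2F)cc(=O)[nH]1` gives 85000 nM. For compound 2 `O=c1cc(Cc2c(F)cccc2F)nc(N2CCCC2)[nH]1` the read-out is only a limit of the assay, > 86000 nM, so that compound 2 sits at the limit of > 86000 nM in this assay, at which 1 of the 3 values shown sits. The change pyrrolidin-1-yl in place of methyl(propyl)amino on an aromatic carbon thus gave an at least 1.0-fold higher number from compound 1 to compound 2 (0.00 log units; that floor lies within the scatter). For compound 3 `CCCN(C)c1nc(C(C)c2c(F)cccc2F)c(C)c(=O)[nH]1` the read-out is again a limit, > 78000 nM, and compound 3 sits at the limit of > 78000 nM in this assay, at which 1 of the 3 values shown sits. The difference between the core of compound 3 and the core of compound 1 is not broken down here. Compound 4 `Cc1c(C(C)c2c(F)cccc2F)nc(N2CCCC2)[nH]c1=O` carries the change (pyrrolidin-1-yl in place of methyl(propyl)amino on an aromatic carbon); the surroundings differ, as the place is here para to a methyl group and meta to a large group rather than meta to a group of 9 heavy atoms, so it is the same kind of change, not the same. The step for compound 4 is expected to be a step that the limit leaves unreadable from compound 3 to compound 4, resting on an at least 1.0-fold higher number from compound 1 to compound 2 (0.00 log units; that floor lies within the scatter). Compound 4 is therefore estimated at 80000 nM, within 40000 nM to 160000 nM.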

Compound 4, half-maximal cytotoxic concentration: > 78000 nM
Compound 4: a limit, no number; the forecaster's own chance of this, stated with the estimate: 70%; the middle value does not contradict the limit.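

In this assay compound 3 and compound 4 both give only limits, not numbers, so no step can be read between them. As far as these compounds go, whether pyrrolidin-1-yl in place of methyl(propyl)amino shifts the read-out on either core stays open.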